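Furanyl and thienyl nucleosides: cell growth inhibition notes

A few compounds are considered here, and "the series" means these few. Any claim that something is new, unique, unknown or untested is made for them only; others in the source may bear on it.

Measured compounds:
- compound 1, `O=c1[nH]cnc2c1c(-c1ccoc1)cn2[C@@H]1O[C@H](CO)[C@@H](O)[C@H]1O`: > 100000 nM in an ADME assay on BJ cells (Homo sapiens), read by MTT assay, with a stated time of 72 h; on this read-out higher numbers stand for weaker inhibition and lower numbers for stronger inhibition
- compound 2, `COc1ncnc2c1c(-c1ccoc1)cn2[C@@H]1O[C@H](CO)[C@@H](O)[C@H]1O`: 28800 nM
- compound 3, `O=c1[nH]cnc2c1c(-c1cccs1)cn2[C@@H]1O[C@H](CO)[C@@H](O)[C@H]1O`: > 100000 nM

The value of compound 1 is a limit of the assay, not a number. The value of compound 3 is likewise a limit. Among the measured compounds shown here, compound 2 is the only compound that gives a number here. The difference between the core of compound 1 and the core of compound 2 is not broken down here.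

The change thiophen-2-yl in place of furan-3-yl on an aromatic carbon gives a step that the two limits leave unreadable from compound 1 to compound 3, since both compounds sit at the limit of > 100000 nM in this assay, at which 2 of the 3 values shown sit.

Compound 4, `COc1ncnc2c1c(-c1cccs1)cn2[C@@H]1O[C@H](CO)[C@@H](O)[C@H]1O`, is not yet measured. It carries the same change as above, (thiophen-2-yl in place of furan-3-yl on an aromatic carbon), made on the core of compound 2. The measured pair gives no readable size for this change, so the expectation rests on compound 2 alone, which gives 28800 nM. The expected step is a 1.0-fold higher number from compound 2 to compound 4 (0.02 log units; within the scatter). For compound 4 the estimate is 30000 nM, with a likely range from 8000 nM to 100000 nM.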

Compound 4, half-maximal inhibitory concentration: 62800 nM
For compound 4 the middle estimate is 2.1-fold (0.32 log units) below the measured one; low and high end bracket the measured number.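

In this assay, thiophen-2-yl in place of furan-3-yl on an aromatic carbon gives a 2.2-fold higher number from compound 2 to compound 4 (0.34 log units; beyond the scatter), a modest step that holds on the core of compound 2. On the core of compound 1 the same change cannot be read, so the series gives no comparison of its size on the two cores, since compound 1 and compound 3 both sit at a limit and not at a number: the limit of > 100000 nM in this assay, at which 2 of the 4 values shown sit. The step therefore rests on a single pair and shows neither that the change carries from one core to the other nor that it fails to do so.

Still open, on these data alone, is how an amine or a longer alkyl chain would read in this assay if it took the place of thiophen-2-yl on the same aromatic carbon of the core of compound 2. Also open, as far as these compounds go, is whether any such group would bring a compound on the core of compound 1 off the limit and give a number there.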